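A few compounds are considered here, and "the series" means these few. Any claim that something is new, unique, unknown or untested is made for them only; others in the source may bear on it.

Measured compounds:
- compound 1 `C[C@@H](O[C@@H]1CN(C(=O)N(C)C)C[C@H]1c1ccc(F)cc1)c1cc(C(F)(F)F)cc(C(F)(F)F)c1`: 0.38 nM
- compound 2 `CCNC(=O)N1C[C@@H](O[C@H](C)c2cc(C(F)(F)F)cc(C(F)(F)F)c2)[C@H](c2ccc(F)cc2)C1`: 0.1 nM
- compound 3 `CC1=C(N2C[C@@H](O[C@H](C)c3cc(C(F)(F)F)cc(C(F)(F)F)c3)[C@H](c3ccc(F)cc3)C2)CCC1=O`: 0.13 nM

All three share one core and differ only in the group carried on the ring amine nitrogen. In a binding assay on CHO cells for displacement of a labelled ligand from Substance-P receptor (Homo sapiens) (on this read-out higher numbers stand for weaker inhibition and lower numbers for stronger inhibition), compound 3 gives 0.13 nM, which places it second highest of the three numbers. It sits close to compound 2, with a 1.3-fold higher number from compound 2 to compound 3 (0.11 log units; within the scatter), and well apart from compound 1, with a 2.9-fold lower number from compound 1 to compound 3 (0.47 log units; beyond the scatter).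

Compound 4 `C[C@@H](O[C@@H]1CN(C2=CC(=O)N(C)C2)C[C@H]1c1ccc(F)cc1)c1cc(C(F)(F)F)cc(C(F)(F)F)c1` is not yet measured. Going from compound 3 to compound 4 the change is a group of 7 heavy atoms (5 carbon, 1 nitrogen, 1 oxygen; one five-membered non-aromatic ring with 1 hetero atom) in place of a group of 7 heavy atoms (6 carbon, 1 oxygen; one five-membered non-aromatic ring of carbon only), on an amine nitrogen in a ring. The entering group keeps the same size and the same single hydrogen-bond acceptor as the leaving group, but one ring carbon is exchanged for a nitrogen.

Going by the values given here, no measured step exchanges one such ring group for another, so the expectation rests on the pattern that the ring-bearing compound 3 and the urea compound 2 land within the scatter of each other, while only compound 1, with a 3.8-fold lower number from compound 1 to compound 2 (0.58 log units; beyond the scatter) and a 2.9-fold lower number from compound 1 to compound 3 (0.47 log units; beyond the scatter), stands apart. The step from compound 3 to compound 4 is therefore expected to be small, a 1.5-fold higher number from compound 3 to compound 4 (0.19 log units; within the scatter), with no clear direction beyond the scatter.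

Compound 4 is estimated to give 0.2 nM in this assay, within a range from 0.06 nM to 0.7 nM.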

Compound 4, half-maximal inhibitory concentration: 0.12 nM
Compound 4: middle estimate off by 1.7-fold (0.22 log units), on the high side; low and high end bracket the measured number.
By their numbers in this assay, from the lowest: compounds 2, 4 and 3 (each within the scatter of the next); then compound 1.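

In this assay, swapping one ring carbon of the group on the amine nitrogen for a nitrogen, with the group's size and its single hydrogen-bond acceptor unchanged, gives a change that stays within the scatter (a 1.1-fold lower number from compound 3 to compound 4 (0.03 log units; within the scatter)). Going by these compounds alone, this is the first direct comparison of two such ring groups, and it shows that at this position the all-carbon ring and the ring with a hetero atom cannot be told apart in this read-out; the new ring group also cannot be told apart from the ethyl urea (a 1.2-fold higher number from compound 2 to compound 4 (0.08 log units; within the scatter)), while the gap to the dimethyl urea lies beyond the scatter (a 3.2-fold lower number from compound 1 to compound 4 (0.50 log units; beyond the scatter)). No measured evidence is available to explain why these groups match or why the dimethyl urea stands apart.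

On these data alone, whether a carboxylic acid or an amine on a longer chain, carried on the same ring nitrogen, would keep numbers like these remains open. So does whether the match between the two ring groups would hold in any read-out other than this binding assay.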